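The compounds below may be only part of what the source reports. "The series", "measured", "known", "first", "only" and "open" are said of these compounds alone.

Three closely related compounds were examined in an ADME assay on RAW264.7 cells (Mus musculus) for cytotoxicity, read by MTT assay, with a stated time of 24 h, tested at 1.25 ug/mL; a lower number here means a stronger effect, a higher number a weaker effect of the compound at the concentration tested. Compound 1, with the structure `COc1cc(C(=O)/C=C/c2cccc(OC)c2OC)ccc1O`, gives 97.5% in this assay. Compound 2, with the structure `COc1ccc(C(=O)CCc2ccc(OC)cc2OC)c(O)c1`, gives 97.8% in this assay. Compound 3, with the structure `COc1ccc(CCCc2ccc(OC)cc2O)cc1`, gives 98.9% in this assay. Among the compounds with values here, all three numbers lie within the usual scatter of one another, so none of the three can be told apart on these data: compound 2 sits nearest to compound 1 and furthest from compound 3, yet both gaps are inside the scatter, and no compound can be called stronger or weaker than another.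

The step of interest leads from compound 2 to compound 4, whose structure is `COc1ccc(CCC(=O)c2ccc(OC)cc2O)cc1` and which has not yet been measured in this assay. The change is hydrogen in place of methoxy on an aromatic carbon.

Within the data shown here, since every measured compound leaves the cells essentially unaffected at this concentration, and no step between the measured compounds reaches beyond the scatter, the step from compound 2 to compound 4 is expected to be none beyond the scatter, that is a number 0.3 percentage points lower from compound 2 to compound 4 (within the scatter) in this assay. Compound 4 is accordingly estimated to give 97.5% in this assay, with an expected range from 92% to 101%.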

Compound 4, a percentage reported as activity, at one concentration (the size of the read-out at that concentration, not a potency): 95.1%
Estimate against measurement, compound 4: 2.4 percentage points above, and the stated range covers the measured number.
By their numbers in this assay, from the lowest: compounds 4, 1, 2 and 3 (each within the scatter of the next).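

Within the data shown here, this is the first pair that differs in one place, so it gives the first direct reading of a single change: hydrogen in place of methoxy on an aromatic carbon, ortho to a large group and meta to a methoxy group. In this assay, that change is a number 2.7 percentage points lower from compound 2 to compound 4 (within the scatter), so at this concentration the methoxy group at this position can be exchanged for hydrogen without a difference that these data can separate from the scatter. No accompanying measurement bears on this result, so the data offer no explanation for it.

The compounds shown leave open whether the same holds for a larger or chemically different replacement on this aromatic carbon, such as an amine, a carboxylic acid or a longer alkoxy chain. They also leave open whether this change would remain within the scatter at a higher concentration, where the cells might no longer be left essentially unaffected, or on a core with a different linking chain.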